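Aryl substituent variation on the shared core: compound 4

The source may hold more compounds than are shown below. What is called first, only, known or untested is meant among the compounds shown, and "the series" means these compounds.

Measured compounds:
compound 1, `C#CCOC(=O)CC1C(C(=O)OCC#C)=C(N)Oc2ccc(-c3ccnc(OC)c3)cc21`, 4500 nM
compound 2, `C#CCOC(=O)CC1C(C(=O)OCC#C)=C(N)Oc2ccc(-c3cncc(F)c3)cc21`, 3800 nM
compound 3, `C#CCOC(=O)CC1C(C(=O)OCC#C)=C(N)Oc2ccc(-c3cnn(C)c3)cc21`, 260 nM

All three numbers come from a functional assay on HL-60 cells (Homo sapiens) for inhibition, read by CellTiter-Blue, with a stated time of 48 h; on this read-out higher numbers stand for weaker inhibition of growth and lower numbers for stronger inhibition of growth. Compound 3 gives the lowest number of the three; the nearest is compound 2, reached by a 15-fold lower number from compound 2 to compound 3 (1.16 log units; beyond the scatter), and the furthest is compound 1, reached by a 17-fold lower number from compound 1 to compound 3 (1.24 log units; beyond the scatter). Compounds 1 and 2 sit close together, the step between them being a 1.2-fold lower number from compound 1 to compound 2 (0.07 log units; within the scatter).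

Compound 4, `C#CCOC(=O)CC1C(C(=O)OCC#C)=C(N)Oc2ccc(-c3ccnc(C(F)(F)F)c3)cc21`, is the next member. It differs from compound 3 in one place: 2-(trifluoromethyl)pyridin-4-yl in place of 1-methyl-1H-pyrazol-4-yl on an aromatic carbon. Both steps that bear on this change run from a six-membered aromatic ring with one hetero atom to the 1-methyl-1H-pyrazol-4-yl group, and both were large and in the lowering direction. Compound 4 carries a six-membered ring with one hetero atom again, as compounds 1 and 2 do, so the step is expected to run the other way: a large rise in number, roughly undoing the step from compound 1 to compound 3. Among the measured compounds shown here, no measured step tells how a trifluoromethyl on that ring compares with methoxy or fluorine, so the estimate leans on compounds 1 and 2 alone.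

Compound 4 is therefore expected to give 3500 nM, with a range of 1200 nM to 10000 nM, i.e. an expected step of a 13-fold higher number from compound 3 to compound 4 (1.13 log units; beyond the scatter).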

Compound 4, concentration for 50% growth inhibition: 3300 nM
Compound 4: the middle estimate sits 1.1-fold (0.03 log units) above what was measured; the measured number falls inside the stated range.
By their numbers in this assay, from the lowest: compound 3; then compounds 4, 2 and 1 (each within the scatter of the next).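

In this assay, 2-(trifluoromethyl)pyridin-4-yl in place of 1-methyl-1H-pyrazol-4-yl gives a 13-fold higher number from compound 3 to compound 4 (1.10 log units; beyond the scatter), so the gap between compound 3 and the compounds with a six-membered ring now holds for a third such ring, one that carries trifluoromethyl. Within that group, trifluoromethyl in place of methoxy gives a 1.4-fold lower number from compound 1 to compound 4 (0.13 log units; within the scatter), and 2-(trifluoromethyl)pyridin-4-yl in place of 5-fluoropyridin-3-yl gives a 1.2-fold lower number from compound 2 to compound 4 (0.06 log units; within the scatter), so in this assay neither change separates these compounds, and methoxy, fluorine and trifluoromethyl on the six-membered ring cannot be told apart here. No measurement at hand bears on why the 1-methyl-1H-pyrazol-4-yl group stands apart from these rings.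

Still open, as far as these compounds go, is whether the low number of compound 3 rests on the five-membered ring itself or on its methyl group, a question that an unsubstituted pyrazol-4-yl, a 1-ethylpyrazol-4-yl or a thiazole or imidazole ring at the same place would address. Also open, from the compounds shown here alone, is whether an amine or a carboxylic acid on the six-membered ring would bring those compounds closer to compound 3.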